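From ethyl to 2-chloroethenyl at the assay limit

The source may report more compounds than this note shows. Statements on the series, on what has been measured and on what is new or still open speak of the compounds shown alone.

Values measured so far in a functional assay on CCRF-HSB-2 cells (Homo sapiens) for antiproliferative activity (on this read-out lower numbers stand for stronger inhibition and higher numbers for weaker inhibition), are these:
- Compound 1 `O=c1[nH]c(=O)n([C@H]2S[C@H](CO)[C@@H](O)[C@@H]2O)cc1I` gives > 100 ug/mL (a limit)
- Compound 2 `CCc1cn([C@@H]2S[C@H](CO)[C@@H](O)[C@@H]2O)c(=O)[nH]c1=O` gives > 100 ug/mL (a limit)
- Compound 3 `Nc1ncnc2c1ncn2[C@H]1S[C@H](CO)[C@@H](O)[C@@H]1O` gives > 100 ug/mL (a limit)

Compound 2 gives > 100 ug/mL in this assay and this is a limit of the assay, not a number. Among the measured compounds shown here, it has no measured number to be ranked against, since the record so far is the limit of > 100 ug/mL in this assay, at which 3 of the 3 values shown sit, and no compound has yet given a true value.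

Compound 4 `O=c1[nH]c(=O)n([C@@H]2S[C@H](CO)[C@@H](O)[C@@H]2O)cc1/C=C/Cl` carries 2-chloroethenyl in place of ethyl on an aromatic carbon and is still to be measured. For the measured compounds named here, no pair of measured compounds shows what a change at this place does. The expected step is a number no higher from compound 2 to compound 4 (the limit leaves the size open) and it is not expected to go beyond the scatter in either direction. Another limit is the likeliest report. In this assay compound 4 is estimated at 100 ug/mL with an expected range from 40 ug/mL to 250 ug/mL for a single measurement.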

Compound 4, half-maximal inhibitory concentration: > 100 ug/mL
Compound 4: only a limit was reported; the forecaster's own chance of this, stated with the estimate: 80%; the middle value lies on the limit itself.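

Compound 2 and compound 4 both end at a limit of the assay rather than a number, so no step can be read between them: the limit of > 100 ug/mL in this assay, at which 4 of the 4 values shown sit.

The compounds shown leave open whether 2-chloroethenyl in place of ethyl changes anything in this assay, and whether any compound on this core gives a true value.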